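A few compounds are considered here, and "the series" means these few. Any claim that something is new, unique, unknown or untested is made for them only; others in the source may bear on it.

Working notes on the series. Compound 1 `Nc1cc(N)c2nc(-c3ccccc3)c(Oc3ccc(Cl)c(Cl)c3)nc2c1` is the reference point. In a functional assay on NCI-H23 cells (Homo sapiens) for inhibition, read by sulforhodamine B assay, with a stated time of 48 h (a higher number here means that more compound is tolerated, a lower number that less compound is tolerated), compound 1 gives only a limit, < 100000 nM, and no number. The other measured member, compound 2 `CCOC(=O)[C@H](CCC(=O)O)NC(=O)c1ccc(CNc2nc3cc(N)cc(N)c3nc2-c2ccccc2)cc1`, likewise gives only a limit in this assay, < 100000 nM. Among the measured compounds shown here, both values therefore sit at the same edge of the range, (the limit of < 100000 nM in this assay, at which 2 of the 2 values shown sit), and the measured set contains no step between compounds that differ in one place, so no measured change is available to calibrate the series.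

Compound 3 `Nc1cc(N)c2nc(-c3ccccc3)c(NCc3ccc(F)cc3)nc2c1` is the next member and has not yet been measured. Against compound 1 it carries the change ((4-fluorobenzyl)amino in place of 3,4-dichlorophenoxy on an aromatic carbon), in words: (4-fluorobenzyl)amino in place of 3,4-dichlorophenoxy on an aromatic carbon. On these data alone, the size of this step in this assay is unknown; the expected step from compound 1 to compound 3 is a step that the limit leaves unreadable from compound 1 to compound 3, kept wide. The estimate for compound 3 in this assay is 30000 nM, between 5000 nM and 100000 nM, and a further limit rather than a number is the likelier outcome.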

Compound 3, concentration lethal to 50% of the cells: 8910 nM
Compound 3: middle estimate off by 3.4-fold (0.53 log units), on the high side; low and high end bracket the measured number.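

No step from compound 1 to compound 3 can be read, because compound 1 gives only a limit and no number: the limit of < 100000 nM in this assay, at which 2 of the 3 values shown sit.

The compounds shown leave open how large the effect of (4-fluorobenzyl)amino in place of 3,4-dichlorophenoxy on an aromatic carbon is in this assay.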